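The compounds below may be only part of what the source reports. "The series", "measured", "known", "first", "only" and "open" are said of these compounds alone.

Measured compounds in a functional assay on HeLa cells (Homo sapiens) for antiproliferative activity, read by MTT assay, with a stated time of 48 h; a higher number here means a weaker inhibitor, a lower number a stronger inhibitor:
- compound 1 `CS(=O)(=O)c1ccc(Nc2ncc(F)c(Nc3nc4ccccc4s3)n2)cc1`, compound 1 gives 3170 nM
- compound 2 `Cc1cnc(Nc2ccc([N+](=O)[O-])cc2)nc1Nc1nc2ccccc2s1`, compound 2 gives 34300 nM
- compound 3 `COc1cccc(Nc2ncc(C)c(Nc3nc4ccccc4s3)n2)c1`; for compound 3 the assay reports only a limit, > 50000 nM

Compound 1 holds the lowest of the two numbers in this assay; its nearest neighbour is compound 2, and that gap is beyond the scatter. Among the measured compounds shown here, the only step between measured compounds swaps the aryl group on the amine nitrogen, an at least 1.4-fold higher number from compound 2 to compound 3 (0.16 log units; that floor lies within the scatter), and ends at a limit (the limit of > 50000 nM in this assay, at which 1 of the 3 values shown sits), so its size is not fixed.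

Compound 4 `CS(=O)(=O)c1ccc(Nc2ncc(F)c(Nc3nc4ccc(F)cc4s3)n2)cc1` differs from compound 1 in one place: fluoro in place of hydrogen on an aromatic carbon. For the measured compounds named here, no measured pair changes the fused ring system, so nothing here bears directly on this step; a small substituent added to the shared core is the whole change. The expectation is therefore a step of a 1.1-fold lower number from compound 1 to compound 4 (0.02 log units; within the scatter) in this assay that stays within the scatter, in no clear direction. Compound 4 is estimated at 3000 nM, with a range from 1200 nM to 8000 nM.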

Compound 4, half-maximal inhibitory concentration: > 50000 nM
Compound 4: only a limit was reported; the forecaster's own chance of this, stated with the estimate: 5%; middle value at least 16-fold (1.22 log units) from the limit.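

In this assay, fluoro in place of hydrogen on an aromatic carbon of the fused system gives an at least 15-fold higher number from compound 1 to compound 4 (1.19 log units; beyond the scatter), so a change of one heavy atom at this position is enough to move the series from a measured value to a limit. The only earlier step, an at least 1.4-fold higher number from compound 2 to compound 3 (0.16 log units; that floor lies within the scatter), changed the aryl group on the nitrogen and has a floor within the scatter, whereas this is the only step shown on the fused system and the only one beyond the scatter. Compound 4 gives a limit, not a number, as does compound 3: the limit of > 50000 nM in this assay, at which 2 of the 4 values shown sit.

The size of the step stays unfixed, and a single substituent at this carbon cannot show whether the loss is specific to fluoro. Chloro, methyl, methoxy or an amine at the same carbon would separate those readings.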